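The source may report more compounds than this note shows. Statements on the series, on what has been measured and on what is new or still open speak of the compounds shown alone.

Working notes on the series. Among the compounds with values here, compound 3 `O=C(/C=C/c1ccc(Cl)cc1)Nc1ccc2ncnc(Nc3cccc(Cl)c3)c2c1` gives 12.4 ug/mL in a functional assay on A549 cells (Homo sapiens) for antiproliferative activity, read by MTT assay, with a stated time of 48 h (a lower number here means a stronger inhibitor, a higher number a weaker inhibitor), the highest of the three numbers so far. Compound 1 `O=C(/C=C/c1ccccc1)Nc1ccc2ncnc(Nc3cccc(Br)c3)c2c1` gives 3.96 ug/mL and compound 2 `Cc1ccc(/C=C/C(=O)Nc2ccc3ncnc(Nc4cccc(Br)c4)c3c2)cc1` gives 3.01 ug/mL in this assay; compound 3 differs from each of them in two places, so its two gaps are read only as what the values show, both beyond the scatter.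

Compound 4 `O=C(/C=C/c1cccc2ccccc12)Nc1ccc2ncnc(Nc3cccc(Cl)c3)c2c1` is not yet measured. Its change from compound 3 is naphthalen-1-yl in place of 4-chlorophenyl on a double-bonded chain carbon bound to a double-bonded chain carbon. Within the data shown here, the only measured step on that same aryl group is a 1.3-fold lower number from compound 1 to compound 2 (0.12 log units; within the scatter), a small change within the scatter. Among the measured compounds shown here, no step exchanges a halogen-bearing ring for a fused bicyclic ring, so the size of the present change is not covered by anything measured.

Taken together, the measured step on this ring argues for little movement, while the standing of compound 3 relative to compound 1 and compound 2 leaves room for a lower number once the 4-chlorophenyl is gone. Compound 4 is therefore expected near 7 ug/mL in this assay, within 2.5 ug/mL to 20 ug/mL, which means an expected step of a 1.8-fold lower number from compound 3 to compound 4 (0.25 log units; within the scatter).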

Compound 4, half-maximal inhibitory concentration: 1.49 ug/mL
The estimate for compound 4 lay 4.7-fold (0.67 log units) above the measured number; the measured number lies below the stated range.
By their numbers in this assay, from the lowest: compound 4; then compounds 2 and 1 (each within the scatter of the next); then compound 3.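

In this assay the exchange of 4-chlorophenyl for naphthalen-1-yl gives an 8.3-fold lower number from compound 3 to compound 4 (0.92 log units; beyond the scatter), so the aryl group on a double-bonded chain carbon bound to a double-bonded chain carbon can move this number beyond the scatter. The earlier methyl for hydrogen exchange on this aryl group (a 1.3-fold lower number from compound 1 to compound 2 (0.12 log units; within the scatter)) did not show this. The exchange raises the group from 7 to 10 heavy atoms and from one to 2 six-membered aromatic rings of carbon only, and it removes the chlorine, while hydrogen-bond donors and acceptors stay at 0, so this one pair cannot separate the gain of a ring from the loss of the chlorine; nothing available on these compounds accounts for the size of the step.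

Going by these compounds, it remains open whether the step depends on how the second ring is attached, which naphthalen-2-yl at this position would address, and whether it needs a ring of carbon only, which quinolin-4-yl or pyridin-3-yl would address. On these data alone, it is also open whether a 4-aminophenyl or 4-carboxyphenyl group at this position would move the number relative to the 4-chlorophenyl of compound 3.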